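From a Flat Ring to a Saturated One

The source may hold more compounds than are shown below. What is called first, only, known or untested is meant among the compounds shown, and "the series" means these compounds.

Compound 1 `COc1cccc(OC)c1C(=O)Nc1c[nH]nc1C(=O)NC1CC1`: > 50000 nM (a limit)
Compound 2 `CO[C@H]1CC[C@H](NC(=O)c2n[nH]cc2NC(=O)c2ccc(N3CCCC3)cc2)CC1`: > 50000 nM (a limit)
Compound 3 `CO[C@H]1CC[C@H](NC(=O)c2n[nH]cc2NC(=O)c2ccc(F)cc2F)CC1`: 11000 nM

For the measured compounds named here, in an ADME assay on MRC5 cells (Homo sapiens) for inhibition, with a stated time of 72 h (a lower number here means that less compound is needed, a higher number that more compound is needed for the effect), compound 3 gives 11000 nM, the only true number among the three. The other two results are limits, not numbers: the limit of > 50000 nM in this assay, at which 2 of the 3 values shown sit.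

Compound 4 `CO[C@H]1CC[C@H](NC(=O)c2n[nH]cc2NC(=O)C2CCC(F)(F)CC2)CC1` has not been measured yet. It carries 4,4-difluorocyclohexyl in place of 2,4-difluorophenyl on a carbonyl carbon. Going by the values given here, no two measured compounds differ in just one place, so this expectation is loose. A moderate move toward a higher number is expected, with the estimated step of a 2.3-fold higher number from compound 3 to compound 4 (0.36 log units; beyond the scatter). In this assay compound 4 is estimated at 25000 nM, with an expected range of 8000 nM to 50000 nM.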

Compound 4, half-maximal effective concentration: > 50000 nM
Compound 4 was reported as a limit (the forecaster's own chance of this, stated with the estimate: 40%); middle value at least 2.0-fold (0.30 log units) from the limit.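

For the compounds shown here, this is the first comparison here that changes only one place, the group on the carbonyl carbon, and it shows that this position affects the result in this assay. Replacing the flat 2,4-difluorophenyl with the saturated 4,4-difluorocyclohexyl, which has the same heavy atoms, gives an at least 4.5-fold higher number from compound 3 to compound 4 (0.65 log units; beyond the scatter). Compound 4 is a limit rather than a number, so the step has no upper end: the limit of > 50000 nM in this assay, at which 3 of the 4 values shown sit.

A plain cyclohexyl or plain phenyl group on the same carbonyl carbon would help show whether the ring type alone accounts for this step. On these data alone, how the fluorine atoms contribute remains open.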